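A few compounds are considered here, and "the series" means these few. Any claim that something is new, unique, unknown or untested is made for them only; others in the source may bear on it.

Measured in a functional assay on HCT-15 cells (Homo sapiens) for cytotoxicity, read by ELISA, with a stated time of 4 days; on this read-out higher numbers stand for weaker inhibition and lower numbers for stronger inhibition:
Compound 1 `Cc1ccsc1-c1cc(-c2ccco2)cc(-c2ccccc2Cl)n1` gives 540 nM
Compound 2 `Cc1ccsc1-c1cc(-c2ccco2)cc(-c2ccc(Cl)cc2)n1` gives 710 nM
Compound 3 `Cc1ccsc1-c1cc(-c2ccoc2)cc(-c2ccc(Cl)cc2)n1` gives 2990 nM

Compound 2 holds the second highest number of the three, within the scatter of compound 1 and clearly lower than compound 3. Compound 4 `Clc1ccc(-c2cc(-c3ccco3)cc(-c3ccc(Cl)s3)n2)cc1` differs from compound 2 by 5-chlorothiophen-2-yl in place of 3-methylthiophen-2-yl on an aromatic carbon with 5-chlorothiophen-2-yl in place of 3-methylthiophen-2-yl, next to the ring nitrogen. The measured steps lie elsewhere: a 1.3-fold higher number from compound 1 to compound 2 (0.12 log units; within the scatter) for 4-chlorophenyl in place of 2-chlorophenyl, and a 4.2-fold higher number from compound 2 to compound 3 (0.62 log units; beyond the scatter) for furan-3-yl in place of furan-2-yl. Neither touches this place, so they offer only a rough size, and in this assay no step beyond the scatter is expected. The expected step is a 1.1-fold higher number from compound 2 to compound 4 (0.05 log units; within the scatter) as an estimate only. Compound 4 is estimated at 800 nM with an expected range from 250 nM to 2600 nM in this estimate.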

Compound 4, half-maximal inhibitory concentration: 1080 nM
Compound 4: the middle estimate sits 1.4-fold (0.13 log units) below what was measured, and the stated range covers the measured number.
By their numbers in this assay, from the lowest: compounds 1, 2 and 4 (each within the scatter of the next); then compound 3.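

In this assay the exchange of 3-methylthiophen-2-yl for 5-chlorothiophen-2-yl next to the ring nitrogen gives a 1.5-fold higher number from compound 2 to compound 4 (0.18 log units; within the scatter) and so cannot be told apart from no difference. Going by these compounds alone, this is the first result at this position, and it shows that the thiophene there can bear a chlorine in place of a methyl without a step beyond the scatter. Nothing available explains this result.

The compounds shown leave open how this position responds to a group other than a substituted thiophene, such as an amine or a carboxylic acid. They also leave open whether the same exchange gives a similar step with furan-3-yl in place of furan-2-yl.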